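Swapping the aryl amine substituent on a shared core

The source may hold more compounds than are shown below. What is called first, only, known or untested is meant among the compounds shown, and "the series" means these compounds.

Of the compounds shown here, three built on one shared core have been tested in a functional assay on HeLa cells (Homo sapiens) for antiproliferative activity, read by spectrophotometry, with a stated time of 2 days; on this read-out higher numbers stand for weaker inhibition of growth and lower numbers for stronger inhibition of growth. Compound 1 `Cc1cc(Cl)ccc1Nc1ncc(C(F)(F)F)c(N2Cc3cccc(N(C)S(C)(=O)=O)c3C2)n1` gives 17400 nM. Compound 2 `CN(c1cccc2c1CN(c1nc(Nc3ccc(Cl)c(C(F)(F)F)c3)ncc1C(F)(F)F)C2)S(C)(=O)=O` gives 11100 nM, and compound 3 `COc1cc(Nc2ncc(C(F)(F)F)c(N3Cc4cccc(N(C)S(C)(=O)=O)c4C3)n2)cc(C(F)(F)F)c1` gives 5100 nM. Compound 2 therefore sits second highest of the three numbers: the step of a 1.6-fold lower number from compound 1 to compound 2 (0.20 log units; within the scatter) stays within the scatter, while the step of a 2.2-fold lower number from compound 2 to compound 3 (0.34 log units; beyond the scatter) is modest but beyond it, and the step of a 3.4-fold lower number from compound 1 to compound 3 (0.53 log units; beyond the scatter) is likewise modest.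

Compound 4 `Cc1ccc(Nc2ncc(C(F)(F)F)c(N3Cc4cccc(N(C)S(C)(=O)=O)c4C3)n2)c(C)c1` has not yet been measured. It differs from compound 2 in one place: 2,4-dimethylphenyl in place of 4-chloro-3-(trifluoromethyl)phenyl on a nitrogen on an aromatic ring. The closest guide is the step from compound 1 to compound 2, which exchanged one substituted phenyl for another on the same nitrogen and moved the number only within the scatter. Among the measured compounds shown here, the only change beyond the scatter among the measured compounds came with the 3-methoxy-5-(trifluoromethyl)phenyl group, which compound 4 does not carry. A step of no more than scatter size is therefore expected in this assay, with the estimate a 1.4-fold higher number from compound 2 to compound 4 (0.13 log units; within the scatter) meaning compound 4 is expected near 15000 nM, within a range from 6000 nM to 40000 nM.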

Compound 4, concentration for 50% growth inhibition: 10600 nM
Beside the measured number, compound 4's estimate is 1.4-fold (0.15 log units) above it; the range from low to high includes it.
By their numbers in this assay, from the lowest: compound 3; then compounds 4, 2 and 1 (each within the scatter of the next).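

In this assay, the step of a 1.0-fold lower number from compound 2 to compound 4 (0.02 log units; within the scatter) shows that this nitrogen can carry an aryl group made of carbon and hydrogen alone, since 2,4-dimethylphenyl and 4-chloro-3-(trifluoromethyl)phenyl cannot be told apart here. The narrower exchange of methyl in place of chloro on an aromatic carbon, seen in the step of a 1.6-fold lower number from compound 1 to compound 4 (0.22 log units; within the scatter), also stays within the scatter. The 3-methoxy-5-(trifluoromethyl)phenyl group of compound 3 now stands apart from a further group, with the step of a 2.1-fold higher number from compound 3 to compound 4 (0.32 log units; beyond the scatter) being modest but beyond the scatter.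

Nothing measured here bears on why the numbers fall as they do. From the compounds shown here alone, it remains open whether the methoxy or the trifluoromethyl of compound 3 goes with its lower number, and how an aryl group carrying an amine or a carboxylic acid would read in this assay.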